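Triazene series: methyl in place of phenyl on the ring nitrogen

The source may hold more compounds than are shown below. What is called first, only, known or untested is meant among the compounds shown, and "the series" means these compounds.

Going by the values given here, compound 1 `CN(C)CCCN(/N=N/c1ccccc1)c1cccc(C(F)(F)F)c1` is the only member with a number in an ADME assay on MDBK cells (Bos taurus) for cytotoxicity, read by MTT assay, with a stated time of 96 h (a higher number here means that more compound is tolerated, a lower number that less compound is tolerated), where compound 1 gives 38000 nM. Compound 2 `Cc1ccc(/N=N/c2ccc(NCCCN(C)C)cc2)cc1` reaches only a limit of the assay, giving > 100000 nM in this assay. Compound 3 `c1ccc(/N=N/N2CCN(c3ccccc3)CC2)cc1` likewise sits at a limit in this assay, with > 100000 nM. Two of the three values shown thus lie at the limit of > 100000 nM in this assay, at which 2 of the 3 values shown sit, so compound 3 stands at the edge of what the assay reports, and no ordering among the limits can be read. Compound 4 `CN1CCN(/N=N/c2ccccc2)CC1` differs from compound 3 by methyl in place of phenyl on an amine nitrogen in a ring. Among the compounds with values here, no measured step of this kind exists in the set; in this assay no shift beyond the usual scatter is expected. Compound 4 is therefore estimated at 100000 nM, within 40000 nM to 300000 nM, most likely again reported as a limit. The step implied is expected to be a number no higher from compound 3 to compound 4 (the limit leaves the size open).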

Compound 4, half-maximal cytotoxic concentration: > 100000 nM
Compound 4: a limit, no number (the forecaster's own chance of this, stated with the estimate: 70%); the middle value lies on the limit itself.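

Going by these compounds alone, compound 3 and compound 4 both sit at a limit, so no step between them can be read: the limit of > 100000 nM in this assay, at which 3 of the 4 values shown sit. The compounds shown leave open whether methyl in place of phenyl on an amine nitrogen in a ring shifts the result in this assay at all.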